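The source may report more compounds than this note shows. Statements on the series, on what has been measured and on what is new or still open speak of the compounds shown alone.

Of the compounds shown here, two sharing one core have numbers so far in a functional assay on the whole organism with Rattus norvegicus as the target; a higher number here means that more compound is needed for the effect, a lower number that less compound is needed. Compound 1 `N=c1sc2cc(OC(F)(F)F)ccc2n1CCS(N)(=O)=O` gives 6 mg/kg, and compound 2 `CSCn1c(=N)sc2cc(OC(F)(F)F)ccc21` gives 3 mg/kg. Among the measured compounds shown here, these two values lie within the usual scatter of each other, so compound 2 cannot be told apart from the only other measured compound. Compound 3 `C[S+]([O-])CCn1c(=N)sc2cc(OC(F)(F)F)ccc21` has not yet been measured and differs from compound 2 in one place: a group of 4 heavy atoms (2 carbon, 1 oxygen, 1 sulfur; no ring) in place of a group of 2 heavy atoms (1 carbon, 1 sulfur; no ring), on a saturated chain carbon bound to an aromatic nitrogen. For the measured compounds named here, only one measured step bears on this change, a 2.0-fold lower number from compound 1 to compound 2 (0.30 log units; within the scatter). That step also exchanged the group on a saturated chain carbon bound to an aromatic nitrogen, putting methylsulfanyl in place of sulfamoylmethyl, and it stayed within the scatter. One step is thin evidence, but it gives no sign of a large effect at this place. The expected change is a 1.3-fold higher number from compound 2 to compound 3 (0.12 log units; within the scatter), so no step beyond the scatter is expected. For compound 3 the estimate is 4 mg/kg, with an expected range from 1.5 mg/kg to 11 mg/kg.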

Compound 3, dose for half-maximal effect: 1.1 mg/kg
Beside the measured number, compound 3's estimate is 3.6-fold (0.56 log units) above it, and the stated range ends above it.
By their numbers in this assay, from the lowest: compound 3; then compounds 2 and 1 (each within the scatter of the next).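

In this assay, the place on a saturated chain carbon bound to an aromatic nitrogen now shows a real response to the group it carries, with a 2.7-fold lower number from compound 2 to compound 3 (0.44 log units; beyond the scatter) where the earlier pair stayed within the scatter. The wider comparison points the same way, with a 5.5-fold lower number from compound 1 to compound 3 (0.74 log units; beyond the scatter) for the exchange on a saturated chain carbon, two bonds along the chain from an aromatic nitrogen, although both steps remain modest. Nothing available here explains why the number fell.

The entering group differs from methylsulfanyl in both its carbon count and its oxygen count, so the compounds shown cannot divide the step between those two differences. Every group shown here contains sulfur, which leaves open how an amine, a carboxylic acid or a sulfur-free longer chain would behave at this place.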